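Trimethoxyphenyl triazole thioethers: a chloroaryl ketone side chain

This account rests on a few compounds, and the source may have more. Where it says the series, first, only, none or still open, it means among the compounds named here.

Compound 1 `Cc1nnc(SCC(=O)c2ccc(Cl)cc2)n1N1C(=O)c2ccccc2C1=O` gives > 200000 nM in a functional assay on A549 cells (Homo sapiens) for cytotoxicity, read by MTT assay, with a stated time of 48 h; on this read-out lower numbers stand for stronger inhibition and higher numbers for weaker inhibition; this is a limit.
Compound 2 `COc1cc(-c2nnc(SCc3ccccc3Cl)n2N2C(=O)c3ccccc3C2=O)cc(OC)c1OC` gives > 200000 nM in this assay; this is a limit.
Compound 3 `C#CCSc1nnc(-c2cc(OC)c(OC)c(OC)c2)n1N1C(=O)c2ccccc2C1=O` gives > 200000 nM in this assay; this is a limit.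

Compound 3 therefore stands at a limit, as do the other two measured compounds, and the step that the two limits leave unreadable from compound 2 to compound 3 cannot be read. The unmeasured compound 4 `COc1cc(-c2nnc(SCC(=O)c3ccc(Cl)cc3)n2N2C(=O)c3ccccc3C2=O)cc(OC)c1OC` differs from compound 3 as follows: (4-chlorophenyl)carbonyl in place of ethynyl on a saturated chain carbon bound to a sulfur. For the measured compounds named here, the only measured step, from compound 2 to compound 3, bears on a change at the same position but is of unreadable size, and compound 1 carries the same (4-chlorophenyl)carbonyl-bearing chain on a different core. Because of the limit of > 200000 nM in this assay, at which 3 of the 3 values shown sit, no step beyond the scatter can be read from the measured compounds, and none is expected for the change to compound 4. Compound 4 is estimated at 200000 nM, within 80000 nM to 500000 nM. The step this estimate implies, a number no higher from compound 3 to compound 4 (the limit leaves the size open), is expected to remain within the scatter, most likely as a further limit.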

Compound 4, half-maximal inhibitory concentration: 9030 nM
For compound 4 the middle estimate is 22-fold (1.35 log units) above the measured one; measured number below the stated range.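

In this assay the (4-chlorophenyl)carbonyl group on a saturated chain carbon bound to a sulfur brings a number that can be read, with an at least 22-fold lower number from compound 3 to compound 4 (1.34 log units; beyond the scatter) and with an at least 22-fold lower number from compound 2 to compound 4 (1.34 log units; beyond the scatter) for the same group in place of 2-chlorophenyl. The chain does not do this on its own: 3,4,5-trimethoxyphenyl in place of methyl on an aromatic carbon gives an at least 22-fold lower number from compound 1 to compound 4 (1.34 log units; beyond the scatter) and so, among these compounds, only the two groups together give a readable value. From the compounds shown here alone, the full size of each step stays open, and the step between compound 2 and compound 3 cannot be read, because the other compounds sit at a limit: the limit of > 200000 nM in this assay, at which 3 of the 4 values shown sit.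

Going by these compounds, whether the carbonyl or the chlorine carries the change remains open. So does what an amine or a carboxylic acid in place of the (4-chlorophenyl)carbonyl group would give.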